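A few compounds are considered here, and "the series" means these few. Any claim that something is new, unique, unknown or untested is made for them only; others in the source may bear on it.

Among the compounds with values here, compound 1 `Cc1nc(-c2ccc(C(F)(F)F)cc2)sc1CNc1ccc(CCC(=O)O)cc1` in a functional assay on CHO cells for agonist activity at Free fatty acid receptor 1 (Homo sapiens) (on this read-out higher numbers stand for an effect only at larger amounts of compound and lower numbers for an effect already at smaller amounts), gives 67.6 nM, the only plain number among the two compounds measured so far. Compound 2 `Cc1nc(-c2ccc(C(F)(F)F)cc2)sc1CNc1ccc(CCCC(=O)O)cc1` in this assay gives < 10000 nM, and this is a limit of the assay rather than a number. The step from compound 1 to compound 2 is thus a step that the limit leaves unreadable from compound 1 to compound 2. Compound 3 `Cc1nc(-c2ccc(C(F)(F)F)cc2)sc1CNc1ccc(OCC(=O)O)cc1` differs from compound 1 by carboxymethoxy in place of 2-carboxyethyl on an aromatic carbon: the acid keeps the same distance from the ring in chain atoms, but the chain now starts with an oxygen rather than a carbon. Within the data shown here, no measured step speaks directly to this change, and the one measured step is unreadable, so no direction is set by the data. Compound 3 in this assay is expected to give about 110 nM, within 30 nM to 450 nM. The estimated step from compound 1 to compound 3 is a 1.6-fold higher number from compound 1 to compound 3 (0.21 log units; within the scatter), a change expected to stay near the scatter.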

Compound 3, half-maximal effective concentration: 288 nM
For compound 3 the middle estimate is 2.6-fold (0.42 log units) below the measured one, within the range that was stated.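

Within the data shown here, the exchange of 2-carboxyethyl for carboxymethoxy on this aromatic carbon is the first readable step at this position, and it gives a 4.3-fold higher number from compound 1 to compound 3 (0.63 log units; beyond the scatter) in this assay. The two groups have the same count of heavy atoms, and one carbon is exchanged for an oxygen, so this position responds to more than the size of the group: a higher number here means that more compound is needed for the effect. The steps involving compound 2 cannot be read, because compound 2 has only a limit of the assay and not a number: the limit of < 10000 nM in this assay, at which 1 of the 3 values shown sits.

The compounds shown do not tell why the oxygen-containing chain gives the higher number. They also leave open how a chain that starts with a sulfur atom or an amine nitrogen would behave at this position.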